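Trifluoromethyl placement on the phenyl group of compound 2

The source may hold more compounds than are shown below. What is called first, only, known or untested is meant among the compounds shown, and "the series" means these compounds.

Going by the values given here, in a functional assay on MIA PaCa-2 cells (Homo sapiens) for inhibition, read by MTT assay, with a stated time of 72 h (a lower number here means a stronger inhibitor, a higher number a weaker inhibitor), compound 2 `COc1cc(NC(C)CCCNC(=O)Nc2ccc(C(F)(F)F)cc2)c2ncccc2c1` gives 8400 nM, the only exact number so far. Compound 1 `COc1cc(NC(C)CCCNC(=O)NNC(=O)Nc2ccc(Cl)cc2)c2ncccc2c1` gives >= 250000 nM, which is a limit of the assay and not a number. Among the compounds with values here, the single measured step, an at least 29-fold lower number from compound 1 to compound 2 (1.47 log units; beyond the scatter), is large, and its size rests on that limit, as the limit of >= 250000 nM in this assay, at which 1 of the 2 values shown sits, records.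

Compound 3 `COc1cc(NC(C)CCCNC(=O)Nc2cccc(C(F)(F)F)c2)c2ncccc2c1` is reached from compound 2 by one change: 3-(trifluoromethyl)phenyl in place of 4-(trifluoromethyl)phenyl on an amide-type nitrogen. The measured step swapped a different group at this nitrogen, so it shows that the site can matter in this assay but gives no measure of a trifluoromethyl shift. No step beyond the scatter is therefore expected, with no firm direction. The expected step is a 1.1-fold lower number from compound 2 to compound 3 (0.02 log units; within the scatter). Compound 3 is estimated at 8000 nM, with an expected range of 3000 nM to 22000 nM.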

Compound 3, half-maximal inhibitory concentration: 17000 nM
Estimate against measurement, compound 3: 2.1-fold (0.33 log units) below; low and high end bracket the measured number.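

In this assay, 3-(trifluoromethyl)phenyl in place of 4-(trifluoromethyl)phenyl on the amide-type nitrogen gives a 2.0-fold higher number from compound 2 to compound 3 (0.31 log units; beyond the scatter), so moving the trifluoromethyl group on the phenyl ring, with the atom count unchanged, is enough to register a modest change at this site. The large gap to the group in compound 1 also holds for the new isomer, with an at least 14-fold lower number from compound 1 to compound 3 (1.16 log units; beyond the scatter). Compound 1 gives a limit of the assay and not a number, so that step is a bound only: the limit of >= 250000 nM in this assay, at which 1 of the 3 values shown sits.

The compounds shown leave open whether the trend between these two placements carries over to other groups on the phenyl ring, such as a nitrile, an amine or a carboxylic acid. They also leave open how a longer chain to the amide-type nitrogen would read in this assay.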